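A few compounds are considered here, and "the series" means these few. Any claim that something is new, unique, unknown or untested is made for them only; others in the source may bear on it.

Measured compounds:
Compound 1 `CCCCc1ccc(-c2ccc3ncc(C(=O)OCC)cc3c2)cc1` — in a functional assay on RD cells (Homo sapiens) for inhibition, read by luminescence and ATP content, with a stated time of 72 h (on this read-out lower numbers stand for higher toxicity in this test and higher numbers for lower toxicity in this test), compound 1 gives > 7400 nM, which is a limit of the assay rather than a number.
Compound 2 `CCCCc1ccc(-c2ccc3ncc(-c4noc(CC)n4)cc3c2)cc1` — in this assay compound 2 gives > 7400 nM, likewise a limit of the assay.

Compound 2 thus stands only at a limit in this assay, and both values shown sit at that same limit (the limit of > 7400 nM in this assay, at which 2 of the 2 values shown sit). Among the compounds with values here, the single measured step, a step that the two limits leave unreadable from compound 1 to compound 2, is therefore unreadable in size. Compound 3 `CCc1nc(-c2cnc3ccc(-c4ccc(NC(C)=O)cc4)cc3c2)no1` differs from compound 2 by acetamido in place of butyl on an aromatic carbon. Within the data shown here, no measured step bears on this change. In this assay compound 3 is expected to give about 10000 nM, within 4000 nM to 30000 nM, most probably again only a limit. The step that the limit leaves unreadable from compound 2 to compound 3 is expected to stay within the scatter.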

Compound 3, half-maximal cytotoxic concentration: > 7400 nM
Compound 3: no number, only a limit (the forecaster's own chance of this, stated with the estimate: 80%); the middle value is on the limit's open side.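

No size can be read for the change from compound 2 to compound 3, since both values are limits, not numbers: the limit of > 7400 nM in this assay, at which 3 of the 3 values shown sit.

The compounds shown leave open how toxic any of them actually is in this assay, and whether swapping butyl for acetamido matters there.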